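Cytotoxicity notes on a dicyanopyrazine-imidazole series

A few compounds are considered here, and "the series" means these few. Any claim that something is new, unique, unknown or untested is made for them only; others in the source may bear on it.

Measured compounds and values in an ADME assay on HEK293 cells (Homo sapiens) for cytotoxicity, read by MTT assay, with a stated time of 48 h; on this read-out higher numbers stand for weaker inhibition and lower numbers for stronger inhibition:

compound 1, `CN(C)CCCn1c(N)c(-c2nc3ccccc3[nH]2)c2nc(C#N)c(C#N)nc21`, 8360 nM
compound 2, `CCN(CC)CCCn1c(N)c(-c2nc3ccccc3[nH]2)c2nc(C#N)c(C#N)nc21`, 7870 nM
compound 3, `CN(C)CCCCn1c(-c2c(N)n(C)c3nc(C#N)c(C#N)nc23)nc2ccccc21`, 7130 nM

In this assay compound 1 gives 8360 nM and compound 2 gives 7870 nM; the difference between them, (diethylamino in place of dimethylamino on a saturated chain carbon, three bonds along the chain from an aromatic nitrogen), produces a 1.1-fold lower number from compound 1 to compound 2 (0.03 log units; within the scatter). Compound 3 gives 7130 nM in this assay; its numbers and those of compound 1 and compound 2 all sit within the scatter of one another, so no order among the three is read. The difference between the core of compound 1 and the core of compound 3 is not broken down here.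

Compound 4, `CCN(CC)CCCCn1c(-c2c(N)n(C)c3nc(C#N)c(C#N)nc23)nc2ccccc21`, is not yet measured. It differs from compound 3 by diethylamino in place of dimethylamino on a saturated chain carbon, four bonds along the chain from an aromatic nitrogen. This is the same kind of change as that from compound 1 to compound 2, but the place is not the same: there the group sits three bonds along the chain from an aromatic nitrogen, here four bonds along the chain from an aromatic nitrogen. Because a 1.1-fold lower number from compound 1 to compound 2 (0.03 log units; within the scatter) stayed within the scatter, the step from compound 3 to compound 4 is expected to be similar, a 1.1-fold lower number from compound 3 to compound 4 (0.03 log units; within the scatter). Compound 4 is therefore estimated at 6700 nM in this assay, with a range from 3500 nM to 13000 nM expected.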

Compound 4, half-maximal inhibitory concentration: 8820 nM
For compound 4 the middle estimate is 1.3-fold (0.12 log units) below the measured one, and the stated range covers the measured number.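

In this assay, diethylamino in place of dimethylamino on a saturated chain carbon, four bonds along the chain from an aromatic nitrogen, gives a 1.2-fold higher number from compound 3 to compound 4 (0.09 log units; within the scatter), so this step shows no change that can be read. Set beside the earlier step, the same change reads alike on the two cores: the same change on two cores in this assay, a 1.1-fold lower number (0.03 log units; within the scatter) from compound 1 to compound 2 and a 1.2-fold higher number (0.09 log units; within the scatter) from compound 3 to compound 4, 1.3-fold (0.12 log units) apart, within the scatter of two such steps This shows only that the change leaves the number within the scatter in both pairs; it does not show a transferable effect of any size, it rests on two pairs alone, and it cannot separate the core from the place of the group, three bonds along the chain in one pair and four bonds in the other.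

The compounds shown leave open whether a cyclic amine such as piperidine or morpholine in place of diethylamino would move the number beyond the scatter. They also leave open what a longer chain would do on either core.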